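The source may report more compounds than this note shows. Statements on the series, on what has been measured and on what is new or still open speak of the compounds shown alone.

Compound 1 `C=CCOc1ccc2c(=O)c(-c3cc(OC)c(OC)cc3OC)coc2c1` carries an allyl group on an oxygen of the shared core. In a functional assay on HUVEC cells (Homo sapiens) for antiproliferative activity, read by MTT assay, with a stated time of 24 h (a higher number here means a weaker inhibitor, a lower number a stronger inhibitor), compound 1 gives > 10000 nM, which is a limit of the assay rather than a measured number. Compound 2 `COc1ccc2c(=O)c(-c3cc(OC)c(OC)cc3OC)coc2c1` differs from compound 1 by hydrogen in place of vinyl on a saturated chain carbon bound to an oxygen on an aromatic ring. In this assay compound 2 gives > 10000 nM, again only a limit. Both values sit at the limit of > 10000 nM in this assay, at which 2 of the 3 values shown sit, so the step that the two limits leave unreadable from compound 1 to compound 2 gives no usable size. Compound 3 `COc1cc(OC)c(-c2coc3cc(OCc4ccc(Cl)cc4)ccc3c2=O)cc1OC` carries 4-chlorophenyl at the same place and in this assay compound 3 gives 4400 nM, a measured number. Among the measured compounds shown here, the step of an at least 2.2-fold lower number from compound 1 to compound 3 (0.35 log units; beyond the scatter) and the step of an at least 2.2-fold lower number from compound 2 to compound 3 (0.35 log units; beyond the scatter) are the only readable changes here, and both point toward a lower number when an aromatic ring is put on that chain carbon.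

Compound 4 `COc1cc(OC)c(-c2coc3cc(OCc4ccc(C(F)(F)F)cc4)ccc3c2=O)cc1OC` is the next member: 4-(trifluoromethyl)phenyl in place of vinyl on a saturated chain carbon bound to an oxygen on an aromatic ring. The closest measured guide is the step of an at least 2.2-fold lower number from compound 1 to compound 3 (0.35 log units; beyond the scatter), with a related aromatic group entering at the same place. A comparable step is therefore expected, namely an at least 2.5-fold lower number from compound 1 to compound 4 (0.39 log units; beyond the scatter). The estimate for compound 4 in this assay is 4000 nM, expected to fall between 1500 nM and 12000 nM.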

Compound 4, half-maximal inhibitory concentration: > 10000 nM
Compound 4 was reported as a limit (the forecaster's own chance of this, stated with the estimate: 25%); at least 2.5-fold (0.39 log units) between middle value and limit.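

Swapping chloro for trifluoromethyl on an aromatic carbon gives an at least 2.2-fold higher number from compound 3 to compound 4 (0.35 log units; beyond the scatter) in this assay, so a change on the added ring alone is enough to lose the measured activity of compound 3. The earlier compounds shown here could be read as saying that any aromatic ring on the chain carbon lowers the number, but compound 4 goes against that reading: the ring is there, and what sits on it matters as well. The steps from compound 1 and from compound 2 to compound 4 cannot be read, since each joins two limits, and compound 3 is now the only compound with a measured number in this small set: the limit of > 10000 nM in this assay, at which 3 of the 4 values shown sit.

From the compounds shown here alone, how far compound 4 actually lies beyond its limit stays unknown, so the true size of the loss from compound 3 is open. Going by these compounds, it is also open whether the chloro of compound 3 is special or whether another group in its place, such as a bromo, a nitrile or an amine, or a plain phenyl with nothing in its place, would give a measured number in this assay.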